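Swapping Ring Substituents Where Only Limits Are Known

The source may report more compounds than this note shows. Statements on the series, on what has been measured and on what is new or still open speak of the compounds shown alone.

Of the compounds shown here, three sharing one core have been tested in an ADME assay on microsomes from liver (Canis lupus familiaris) for metabolic stability; on this read-out higher numbers stand for a longer-lived compound and lower numbers for a shorter-lived compound. Compound 1 `Nc1nc(NCCNc2ncc(-c3ncc[nH]3)c(-c3ccc(Cl)cc3)n2)ccc1[N+](=O)[O-]` gives > 0.5 h, which is a limit of the assay and not a number. Compound 2 `Nc1nc(NCCNc2ncc(-c3ncc[nH]3)c(-c3ccc(C(F)(F)F)cc3)n2)ccc1[N+](=O)[O-]` gives > 0.5 h, again a limit. Compound 3 `Nc1nc(NCCNc2ncc(-c3ncc[nH]3)c(-c3ccc(Cl)cc3F)n2)ccc1[N+](=O)[O-]` gives > 0.5 h, also a limit, so it has no exact place among the others.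

Compound 4 `Nc1nc(NCCNc2ncc(-c3ncc[nH]3)c(-c3ccc(Br)cc3Cl)n2)ccc1[N+](=O)[O-]` has not been measured yet. It carries 4-bromo-2-chlorophenyl in place of the 4-chloro-2-fluorophenyl of compound 3, on an aromatic carbon: 4-bromo-2-chlorophenyl in place of 4-chloro-2-fluorophenyl on an aromatic carbon.

The measured changes that bear on this one all involve the same aromatic group. Fluoro in place of hydrogen is a step that the two limits leave unreadable from compound 1 to compound 3. Trifluoromethyl in place of chloro is a step that the two limits leave unreadable from compound 1 to compound 2. Finally, 4-chloro-2-fluorophenyl in place of 4-(trifluoromethyl)phenyl is a step that the two limits leave unreadable from compound 2 to compound 3.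

None of these steps has a readable size or direction, so the expectation rests only on (the limit of > 0.5 h in this assay, at which 3 of the 3 values shown sit). No step beyond the usual scatter is expected, in either direction, and the estimated step is a step that the limit leaves unreadable from compound 3 to compound 4. Compound 4 is expected at 0.7 h, with an estimated range from 0.4 h to 1.5 h, and the assay may well report only a limit again.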

Compound 4, half-life: > 0.5 h
Compound 4: a limit, no number; the forecaster's own chance of this, stated with the estimate: 80%; the middle value lies beyond the limit too.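

In this assay compound 4 gives > 0.5 h, again a limit and not a number. Among the compounds shown here, no step from compound 1, compound 2 or compound 3 to compound 4 can be read, because all four compounds stand at the same limit: the limit of > 0.5 h in this assay, at which 4 of the 4 values shown sit. The compounds shown leave open how long each one actually lasts and whether these ring changes alter that at all.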